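Working notes on the step from compound 3 to compound 4

A few compounds are considered here, and "the series" means these few. Any claim that something is new, unique, unknown or untested is made for them only; others in the source may bear on it.

Measured compounds:
Compound 1 `C=CC1=C(C(=O)Nc2ccccc2)C(c2ccc(Cl)c(Cl)c2)OC1`: in a functional assay on QGY7701 cells (Homo sapiens) for cytotoxicity, read by MTT assay, with a stated time of 24 h (on this read-out higher numbers stand for weaker inhibition and lower numbers for stronger inhibition), compound 1 gives > 100000 nM, which is a limit of the assay.
Compound 2 `C=CC1=C(C(=O)Nc2ccc(OCC)cc2)C(c2ccc(OC)cc2)OC1`: in this assay compound 2 gives > 100000 nM, which is a limit of the assay.
Compound 3 `C=CC1=C(C(=O)Nc2ccccc2)C(c2ccc(OC)cc2)OC1`: in this assay compound 3 gives > 100000 nM, which is a limit of the assay.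

Compound 3 stands only at a limit; every value shown sits there (the limit of > 100000 nM in this assay, at which 3 of the 3 values shown sit). The two measured steps that end at compound 3, a step that the two limits leave unreadable from compound 1 to compound 3 and a step that the two limits leave unreadable from compound 2 to compound 3, are therefore unreadable in size and direction.

Compound 4 `C=CC1=C(C(=O)NCCC)C(c2ccc(OC)cc2)OC1` differs from compound 3 by propyl in place of phenyl on an amide-type nitrogen. Among the compounds with values here, no measured step touches the amide nitrogen, and the two steps that exist give no readable size, so nothing measured bears on this change. The expectation for compound 4 rests on the limit alone: the step that the limit leaves unreadable from compound 3 to compound 4 is estimated as none beyond the scatter, with a further limit the likeliest outcome. Compound 4 is estimated at 150000 nM, with a range from 30000 nM to 600000 nM.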

Compound 4, half-maximal inhibitory concentration: > 100000 nM
Compound 4: a limit, no number; the forecaster's own chance of this, stated with the estimate: 85%; the middle value lies beyond the limit too.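

No new step can be read: compound 4 is a limit, as are compound 2 and compound 3, so its steps from both have neither size nor direction. All compounds shown stand at one limit: the limit of > 100000 nM in this assay, at which 4 of the 4 values shown sit. The compounds shown leave open which change to the shared core, if any, would give a measurable value in this assay.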